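The source may report more compounds than this note shows. Statements on the series, on what has been measured and on what is new or still open speak of the compounds shown alone.

In a functional assay on K562 cells (Homo sapiens) for cytotoxicity (on this read-out higher numbers stand for weaker inhibition and lower numbers for stronger inhibition), the two measured compounds stand as follows.
Compound 1 `NC(=O)CNC(=O)C(CSCc1ccc(Br)cc1)NC(=O)CCC(N)C(N)=O` gives > 50 uM, which is a limit of the assay and not a number.
Compound 2 `O=CNC(CCC(=O)NC(CSCc1ccc(Br)cc1)C(=O)NCC(=O)O)C(=O)O` gives > 50 uM, likewise a limit of the assay.

Compound 2 thus has no measured number of its own: it sits at the limit of > 50 uM in this assay, at which 2 of the 2 values shown sit, with compound 1 sitting at the same limit. Compound 3 `CC(=O)NC(CCC(=O)NC(CSCc1ccc(Br)cc1)C(=O)NCC(=O)O)C(=O)O` differs from compound 2 in one place: methyl in place of hydrogen on a carbonyl carbon. Going by the values given here, no step between measured compounds is available as a guide, and compound 2 offers no number from which a shift could be measured. The step from compound 2 to compound 3 in this assay is expected to be a step that the limit leaves unreadable from compound 2 to compound 3, none beyond the usual scatter. Compound 3 is therefore expected to give about 70 uM, between 30 uM and 200 uM, and most likely to be reported again only as a limit.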

Compound 3, concentration for 50% inhibition: > 50 uM
Compound 3 gave a limit, no number (the forecaster's own chance of this, stated with the estimate: 85%); the middle value lies beyond the limit too.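

No step from compound 2 to compound 3 can be read, because both stand only at a limit of the assay, not at a number: the limit of > 50 uM in this assay, at which 3 of the 3 values shown sit.

The compounds shown leave open how strongly any of them acts in this assay, and whether formyl and acetyl differ there at all.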